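Chloro Gives Way to Methoxy at the Limit

A few compounds are considered here, and "the series" means these few. Any claim that something is new, unique, unknown or untested is made for them only; others in the source may bear on it.

In a physicochemical assay for solubility, at pH 2 (a higher number here means a more soluble compound, a lower number a less soluble compound), compound 1 `CC(C)Nc1nc(NCc2ccco2)c2ccccc2n1` gives >= 30000 nM, a limit of the assay and not a number. Compound 2 `CC(C)Nc1nc(NCc2ccco2)c2cc(Cl)ccc2n1` gives >= 30000 nM, also only a limit. For the measured compounds named here, the sole measured step is a step that the two limits leave unreadable from compound 1 to compound 2, chloro in place of hydrogen on an aromatic carbon. The evidence amounts to the limit of >= 30000 nM in this assay, at which 2 of the 2 values shown sit. Compound 3 `COc1ccc2nc(NC(C)C)nc(NCc3ccco3)c2c1` departs from compound 2 by methoxy in place of chloro on an aromatic carbon. With no readable size to carry over from a step that the two limits leave unreadable from compound 1 to compound 2, no step beyond the scatter is expected in this assay. The expected change is a number no higher from compound 2 to compound 3 (the limit leaves the size open). For compound 3 the estimate is 30000 nM, expected within 15000 nM to 40000 nM.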

Compound 3, solubility: >= 30000 nM
Compound 3 gave a limit, no number; the forecaster's own chance of this, stated with the estimate: 85%; the middle value sits exactly at the limit.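

For the compounds shown here, compound 1, compound 2 and compound 3 all give only a limit in this assay, and no step among them can be read. The compounds shown leave open what number each would give, and whether chloro or methoxy shifts it.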